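Azetidine-ring replacement by an open sulfamoylethoxy chain at the ring nitrogen

The source may report more compounds than this note shows. Statements on the series, on what has been measured and on what is new or still open speak of the compounds shown alone.

Measured so far:
Compound 1, `[O-][S+]1CC(Nc2nonc2/C(=N/O)Nc2ccc(F)c(Br)c2)C1`: 212 nM
Compound 2, `N=S1(=O)CC(Nc2nonc2/C(=N/O)Nc2ccc(F)c(Br)c2)C1`: 208 nM
Compound 3, `CN(C)S(=O)(=O)CCNc1nonc1/C(=N/O)Nc1ccc(F)c(Br)c1`: 105 nM

All three share one core and differ only in the group on the nitrogen attached to the aromatic ring, tested in an assay on isolated protein for inhibition of Indoleamine 2,3-dioxygenase 1 (Homo sapiens), read by fluorescence, with a stated time of 60 min; on this read-out lower numbers stand for stronger inhibition and higher numbers for weaker inhibition. Compound 2 sits at the second-highest number of the three; its nearest neighbour is compound 1 a 1.0-fold lower number from compound 1 to compound 2 (0.01 log units; within the scatter) and its furthest is compound 3 a 2.0-fold lower number from compound 2 to compound 3 (0.30 log units; within the scatter). For the measured compounds named here, the only step that reaches beyond the scatter is a 2.0-fold lower number from compound 1 to compound 3 (0.31 log units; beyond the scatter), also a modest one.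

Compound 4, `NS(=O)(=O)CCONc1nonc1/C(=N/O)Nc1ccc(F)c(Br)c1`, is not yet measured. Relative to compound 2 the change is a group of 7 heavy atoms (2 carbon, 1 nitrogen, 3 oxygen, 1 sulfur; no ring) in place of a group of 6 heavy atoms (3 carbon, 1 nitrogen, 1 oxygen, 1 sulfur; one four-membered non-aromatic ring with 1 hetero atom), on a nitrogen on an aromatic ring.

The step that bears most on this is a 2.0-fold lower number from compound 2 to compound 3 (0.30 log units; within the scatter), where a four-membered ring group likewise gave way to an open chain bearing a sulfur-dioxygen unit; it stayed within the scatter, and the parallel a 2.0-fold lower number from compound 1 to compound 3 (0.31 log units; beyond the scatter) was only modest. The exchange to compound 4 is of the same kind, so no step beyond the scatter is expected in this assay, with a slight lean toward a lower number. Compound 4 is therefore estimated at 150 nM, with a range from 60 nM to 400 nM. The expected step is a 1.4-fold lower number from compound 2 to compound 4 (0.14 log units; within the scatter).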

Compound 4, half-maximal inhibitory concentration: 87 nM
Compound 4: middle estimate off by 1.7-fold (0.24 log units), on the high side; the measured number falls inside the stated range.
By their numbers in this assay, from the lowest: compounds 4, 3, 2 and 1 (each within the scatter of the next, the first and the last beyond it).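

In this assay, the open 2-sulfamoylethoxy chain clears the scatter against both four-membered ring groups, with a 2.4-fold lower number from compound 2 to compound 4 (0.38 log units; beyond the scatter) and a 2.4-fold lower number from compound 1 to compound 4 (0.39 log units; beyond the scatter), both modest; the open chain of compound 3 had done so only against the ring group of compound 1. The two open chains cannot be told apart at this nitrogen, with a 1.2-fold lower number from compound 3 to compound 4 (0.08 log units; within the scatter), even though 2-sulfamoylethoxy and 2-(dimethylsulfamoyl)ethyl differ in more than one feature. No supporting data bear on this result.

A 2-sulfamoylethyl chain would separate the contribution of the chain oxygen from that of the unsubstituted sulfamoyl end, which these compounds leave entangled. Also open, as far as these compounds go, is whether a carboxylic acid or an amine at the chain end, or a longer chain, would hold the number at this level.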